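Swapping methoxy for trifluoromethyl on a chalcone

The source may hold more compounds than are shown below. What is called first, only, known or untested is meant among the compounds shown, and "the series" means these compounds.

Two chalcones have been tested so far in an ADME assay on HT-29 cells (Homo sapiens) for inhibition, read by trypan blue exclusion, with a stated time of 72 h; a higher number here means a weaker inhibitor of growth, a lower number a stronger inhibitor of growth. Compound 1, `O=C(/C=C/c1ccccc1)c1ccccc1[N+](=O)[O-]`, carries a nitro group on the ring attached to the carbonyl, and in this assay compound 1 gives 8300 nM. Compound 2, `COc1cccc(C(=O)/C=C/c2ccccc2)c1`, instead carries a methoxy group on that ring, and in this assay compound 2 gives 14700 nM. The number for compound 2 sits close to the number for compound 1, and the gap between them falls within the usual scatter of repeated measurements, so the two values are best read as similar.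

The next compound, compound 3, `O=C(/C=C/c1ccccc1)c1cccc(C(F)(F)F)c1`, differs from compound 2 in one place: trifluoromethyl in place of methoxy on an aromatic carbon. Among the compounds with values here, no measured pair shows what such a swap does on this core, so the expectation rests on compound 2 alone. For compound 3 the estimated step of a 1.5-fold lower number from compound 2 to compound 3 (0.17 log units; within the scatter) is a small one, with no direction beyond the scatter.

In this assay compound 3 is expected to give about 10000 nM, within a range from 3000 nM to 30000 nM.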

Compound 3, concentration for 50% growth inhibition: > 20000 nM
Compound 3 was reported as a limit; the forecaster's own chance of this, stated with the estimate: 5%; middle value at least 2.0-fold (0.30 log units) away from the limit.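

In this assay compound 3 gives > 20000 nM, which is a limit of the assay and not a number. Within the data shown here, this is the first single swap on the shared core, and trifluoromethyl in place of methoxy on this aromatic carbon, meta to a large group, gives an at least 1.3-fold higher number from compound 2 to compound 3 (0.13 log units; that floor lies within the scatter), so the change shows no sign of a lower number, though this floor alone does not separate the two compounds beyond the scatter. The true size of the step stays unknown, and only a floor can be stated, because the reading for compound 3 stops at a limit: the limit of > 20000 nM in this assay, at which 1 of the 3 values shown sits.

The compounds shown leave open how far the number for compound 3 lies beyond that limit, and so whether the swap costs little or much in growth inhibition. They also leave open how an amine or a carboxylic acid on the same aromatic carbon would read, and whether the step from methoxy to trifluoromethyl would look the same on another carbon of this ring.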